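The source may hold more compounds than are shown below. What is called first, only, known or untested is meant among the compounds shown, and "the series" means these compounds.

Compound 1 `COc1ccc(C2N=C(SCc3ccc(Cl)cc3)NC(C)=C2C(=O)Nc2ccc(F)cc2)cc1OC`: 20%
Compound 2 `COc1ccc(C2N=C(SCc3ccc(F)cc3)NC(C)=C2C(=O)Nc2ccc(F)cc2)cc1OC`: 15.4%
Compound 3 `CC1=C(C(=O)Nc2ccc(Br)cc2)C(c2ccc(Cl)cc2Cl)N=C(SCc2ccc(Cl)cc2)N1`: 22.1%

Of the compounds shown here, three have been measured in a functional assay on the whole organism (artery, strain albino) with Rattus norvegicus as the target, with a stated time of 900 min, at a dose of 10 mg/kg by the oral route; on this read-out lower numbers stand for less inhibition and higher numbers for more inhibition at the one dose given (going by the name of the read-out). In this assay compound 1 gives 20%. Compound 2 differs from compound 1 by fluoro in place of chloro on an aromatic carbon, and in this assay compound 2 gives 15.4%, so that the step of a number 4.6 percentage points lower from compound 1 to compound 2 (within the scatter) leaves the two within the scatter of each other. Compound 3 is built on a different core; the difference between the cores of compound 1 and compound 3 is not broken down here. In this assay compound 3 gives 22.1%, and its readings against compound 1 and against compound 2 both lie within the scatter, so no order among the three can be drawn.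

Compound 4 `CC1=C(C(=O)Nc2ccc(Br)cc2)C(c2ccc(Cl)cc2Cl)N=C(SCc2ccc(F)cc2)N1` has not yet been measured in this assay. It differs from compound 3 by fluoro in place of chloro on an aromatic carbon, the same change already seen between compound 1 and compound 2, at the same place. The step from compound 3 to compound 4 is expected to be a number 4.1 percentage points lower from compound 3 to compound 4 (within the scatter), a size taken from the earlier step because a number 4.6 percentage points lower from compound 1 to compound 2 (within the scatter) was small. Compound 4 is therefore estimated at 18% in this assay, between 8% and 28%.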

Compound 4, a percentage reported as inhibition, in the whole organism at one dose (the size of the read-out at that dose, not a potency): 23.1%
Beside the measured number, compound 4's estimate is 5.1 percentage points below it; measured number inside the range.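

In this assay, putting 4-fluorobenzyl in place of 4-chlorobenzyl on the second core gives a number 1 percentage points higher from compound 3 to compound 4 (within the scatter), and the two steps on the two cores do not differ: the same change on two cores in this assay, a number 4.6 percentage points lower (within the scatter) from compound 1 to compound 2 and a number 1 percentage points higher (within the scatter) from compound 3 to compound 4, 5.6 percentage points apart, within the scatter of two such steps. On both cores, then, this exchange leaves the read-out within the scatter, and nothing in these two pairs sets one core apart from the other. This does not show that the two cores respond identically, as two small steps can neither reveal nor exclude a modest difference between them, and it says nothing about the change at any other dose or in any other read-out.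

The only groups shown at this place are (4-chlorobenzyl)sulfanyl and (4-fluorobenzyl)sulfanyl, so it remains open how a methoxy group, an amine or a carboxylic acid in place of the halogen would read. It is also open which of the several differences between the core of compound 1 and the core of compound 3 matter, as no pair shown isolates any one of them.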